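Aryl replacement at the biphenyl terminus of the cinnamate amide series

The source may hold more compounds than are shown below. What is called first, only, known or untested is meant among the compounds shown, and "the series" means these compounds.

Measured so far:
compound 1 `COC(=O)/C=C/c1cccc(N(Cc2ccc(-c3ccc(OC)cc3)cc2)C(=O)C(C)C)c1` — 97 nM
compound 2 `COC(=O)/C=C/c1cccc(N(Cc2ccc(-c3cccc(OC(F)(F)F)c3)cc2)C(=O)C(C)C)c1` — 247 nM

Going by the values given here, in an assay on isolated protein with Bile acid receptor (Homo sapiens) as the target (on this read-out lower numbers stand for an effect already at smaller amounts and higher numbers for an effect only at larger amounts of compound), compound 2 stands at the higher of the two numbers recorded so far; the only neighbour is compound 1, and the step of a 2.5-fold higher number from compound 1 to compound 2 (0.41 log units; beyond the scatter) is the sole measured change bearing on this position. Compound 3 `COC(=O)/C=C/c1cccc(N(Cc2ccc(-c3ccc(F)c(Cl)c3)cc2)C(=O)C(C)C)c1` carries 3-chloro-4-fluorophenyl in place of 3-(trifluoromethoxy)phenyl on an aromatic carbon. One step of modest size gives little footing for a swap between two halogenated aryl groups; a shift of a 1.4-fold lower number from compound 2 to compound 3 (0.14 log units; within the scatter) is expected, that is, nothing clearly beyond the scatter. Compound 3 is accordingly estimated at 180 nM, with a range of 70 nM to 450 nM.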

Compound 3, half-maximal effective concentration: 129 nM
The estimate for compound 3 lay 1.4-fold (0.14 log units) above the measured number; low and high end bracket the measured number.
By their numbers in this assay, from the lowest: compounds 1, 3 and 2 (each within the scatter of the next, the first and the last beyond it).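

In this assay the step of a 1.9-fold lower number from compound 2 to compound 3 (0.28 log units; within the scatter) and the step of a 1.3-fold higher number from compound 1 to compound 3 (0.12 log units; within the scatter) leave compound 3 indistinguishable from either neighbour, although those two neighbours are separated beyond the scatter. The 3-chloro-4-fluorophenyl group, with 0 hydrogen-bond acceptors, therefore keeps the number in the range already seen at this position. No supporting data explain how these aryl groups read. Still open, going by these compounds, is how a carboxylic acid or an amine on the terminal aryl group would read. A longer alkyl chain in place of that aryl group is equally unresolved.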